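Methoxy for Fluoro on the Aryl Sulfide Side Chain

The compounds below may be only part of what the source reports. "The series", "measured", "known", "first", "only" and "open" are said of these compounds alone.

Compound 2 `C=C1CC[C@@H]2[C@](C)(CO)[C@H](O)CC[C@@]2(C)[C@@H]1CC(Sc1ccc(F)cc1)C1=CCOC1=O` holds the lower of the two numbers recorded so far in a functional assay on PC-3 cells (Homo sapiens) for inhibition, read by MTT assay, with a stated time of 48 h (a lower number here means a stronger inhibitor, a higher number a weaker inhibitor), where compound 2 gives 16000 nM. For the measured compounds named here, its only neighbour, compound 1 `C=C1CC[C@@H]2[C@](C)(CO)[C@H](O)CC[C@@]2(C)[C@@H]1CC(Sc1ccc([N+](=O)[O-])cc1)C1=CCOC1=O`, gives 17000 nM in this assay, and the change a 1.1-fold lower number from compound 1 to compound 2 (0.03 log units; within the scatter) shows that swapping the group on that aromatic carbon left the number essentially unchanged. Compound 3 `C=C1CC[C@@H]2[C@](C)(CO)[C@H](O)CC[C@@]2(C)[C@@H]1CC(Sc1ccc(OC)cc1)C1=CCOC1=O` differs from compound 2 by methoxy in place of fluoro on an aromatic carbon. Going by the values given here, since the one comparable step stayed within the scatter, no step beyond the scatter is expected here, in either direction. Compound 3 is therefore estimated at 15000 nM, with a range of 7000 nM to 35000 nM, which means an expected step of a 1.1-fold lower number from compound 2 to compound 3 (0.03 log units; within the scatter).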

Compound 3, half-maximal inhibitory concentration: 15000 nM
For compound 3 middle estimate and measured number coincide at the digits printed; measured number inside the range.
By their numbers in this assay, from the lowest: compounds 3, 2 and 1 (each within the scatter of the next).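

In this assay methoxy on this aromatic carbon reads the same as fluoro (a 1.1-fold lower number from compound 2 to compound 3 (0.03 log units; within the scatter)) and the same as nitro (a 1.1-fold lower number from compound 1 to compound 3 (0.05 log units; within the scatter)). Three different groups now sit at this place with no step beyond the scatter, so the position has shown no preference among them. No measurement shown here explains this flat result.

The compounds shown leave open whether an amine, a carboxylic acid or a longer chain at this place would also leave the number unmoved. They also leave open how much the sulfide link itself contributes.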